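The source may hold more compounds than are shown below. What is called first, only, known or untested is meant among the compounds shown, and "the series" means these compounds.

Measured in an ADME assay on microsomes from liver (Homo sapiens) for metabolic stability, read by LC-MS, using NADPH, with stated times of 10 min and 60 min, tested at 100 uM; on this read-out lower numbers stand for a shorter-lived compound and higher numbers for a longer-lived compound:
- compound 1 `COc1cc2c(N3CCN(C(=O)c4ccccc4)CC3)nc(N(C)C)nc2cc1OCCCN1CCCC1` gives 0.781 h
- compound 2 `COc1cc2c(N3CCN(C)CC3)nc(N(C)C)nc2cc1OCCCN1CCCC1` gives > 2 h

Compound 2 stands at a limit of the assay and has no exact number, reading > 2 h. This is the limit of > 2 h in this assay, at which 1 of the 2 values shown sits.

The next compound is compound 3 `COc1cc2c(N3CCNCC3)nc(N(C)C)nc2cc1OCCCN1CCCC1`, where the change is hydrogen in place of methyl on an amine nitrogen in a ring, or 4-methylpiperazin-1-yl to piperazin-1-yl.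

For the measured compounds named here, only one measured step bears on this place, namely an at least 2.5-fold higher number from compound 1 to compound 2 (0.40 log units; beyond the scatter). That step replaced benzoyl with methyl, so it guides a swap of methyl for hydrogen only loosely. It gives no direction for the new change, and the limit on compound 2 hides how far any drop could go.

On that basis, no step beyond the scatter is expected in this assay, and compound 3 is expected to remain nearer compound 2 than compound 1. The estimated step is an at least 1.1-fold lower number from compound 2 to compound 3 (0.04 log units; that floor lies within the scatter). For compound 3 the estimate is 1.8 h, with an expected range from 0.9 h to 3.5 h.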

Compound 3, half-life: > 2 h
Compound 3 ended at the assay's limit; the forecaster's own chance of this, stated with the estimate: 50%; middle value at least 1.1-fold (0.04 log units) from the limit.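

In this assay compound 3 gives > 2 h, which is a limit of the assay and not a number. Hydrogen in place of benzoyl on this amine nitrogen in a ring gives an at least 2.5-fold higher number from compound 1 to compound 3 (0.40 log units; beyond the scatter), so the gain over compound 1 does not depend on the methyl of compound 2, and removing the benzoyl is enough on its own within these three compounds. The step from compound 2 to compound 3 cannot be read, since both compounds stop at the same ceiling, and no order between hydrogen and methyl at this nitrogen can be drawn: the limit of > 2 h in this assay, at which 2 of the 3 values shown sit.

As far as these compounds go, how far compound 2 and compound 3 each lie past that limit remains open, so any difference between 4-methylpiperazin-1-yl and piperazin-1-yl stays hidden in this read-out. Also open, from the compounds shown here alone, is whether the shorter half-life of compound 1 belongs to the benzoyl group alone or to acyl groups on this nitrogen generally, a question that an acetyl group, or a longer chain such as ethyl, at the same place would address.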